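A few compounds are considered here, and "the series" means these few. Any claim that something is new, unique, unknown or untested is made for them only; others in the source may bear on it.

Working notes on the series.

Compound 1 `C#CCOC(=O)/C=C(C)/C=C/CC(C)CCCC(C)(C)OC` gives 4.66 in a physicochemical assay for lipophilicity; on this read-out higher numbers stand for higher lipophilicity and lower numbers for lower lipophilicity. Compound 2 `C=CCOC(=O)/C=C(C)/C=C/CC(C)CCCC(C)(C)OC` gives 5.53 in this assay. The step of a number 0.87 log units higher from compound 1 to compound 2 (beyond the scatter) follows from one change: vinyl in place of ethynyl on a saturated chain carbon bound to an oxygen next to a carbonyl group.

Compound 3 `C#CCSC(=O)/C=C(C)/C=C/CC(C)CCCC(C)C` gives 5.07 in this assay. The difference between the core of compound 3 and the core of compound 1 is not broken down here; their two values alone show the gap.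

Compound 4 `C=CCSC(=O)/C=C(C)/C=C/CC(C)CCCC(C)C` is not yet measured. It differs from compound 3 by vinyl in place of ethynyl on a saturated chain carbon bound to a sulfur. Within the data shown here, this is the same kind of change as the one from compound 1 to compound 2, not the same: there the place was on a saturated chain carbon bound to an oxygen next to a carbonyl group, here it is on a saturated chain carbon bound to a sulfur.

For compound 4 a step of a number 0.78 log units higher from compound 3 to compound 4 (beyond the scatter) is expected, resting on the measured step of a number 0.87 log units higher from compound 1 to compound 2 (beyond the scatter), with a wider range because the place of the change differs. On that basis compound 4 is estimated at 5.85 in this assay, expected between 5.4 and 6.3.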

Compound 4, partition coefficient: 7.97
The estimate for compound 4 lay 2.12 log units below the measured number; measured number outside the range, above it.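

In this assay vinyl in place of ethynyl, on a saturated chain carbon bound to a sulfur, gives a number 2.90 log units higher from compound 3 to compound 4 (beyond the scatter) and so runs in the same direction as a number 0.87 log units higher from compound 1 to compound 2 (beyond the scatter) on the other core, but the modest size of that earlier step does not carry over to this large one. With only these two steps, the data do not show whether the size depends on the place of the change or on another of the differences between the two cores, and they establish no general rule for the series. No evidence bearing on the size of the new step is available.

The compounds shown leave open how either core responds when allyl gives way to a saturated propyl or a longer chain such as butyl. Also open, going by these compounds, is whether a core carrying an amine or a carboxylic acid would show this change as a modest step, a large one, or one in the opposite direction.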